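The source may report more compounds than this note shows. Statements on the series, on what has been measured and on what is new or still open speak of the compounds shown alone.

In a functional assay on Shh Light II cells (Mus musculus) for inhibition, read by a luciferase reporter (on this read-out higher numbers stand for weaker inhibition and lower numbers for stronger inhibition), compound 2 `O=C(NCC1CCC1)N1CCC(c2nc(-c3ccc4ccccc4n3)no2)CC1` gives 410 nM, the highest of the three numbers seen so far. Compound 3 `Cn1c(-c2noc(C3CCN(C(=O)NC4CCS(=O)(=O)CC4)CC3)n2)nc2ccccc21` gives 350 nM, a gap that lies within the scatter of repeated measurements, so these two cannot be ranked against each other. Compound 1 `O=C(Nc1ccccc1Cl)N1CCN(c2nc(-c3ccc4ccccc4n3)no2)CC1` gives 140 nM, a gap that lies beyond the scatter. Compound 4 `COc1ccccc1NC(=O)N1CCC(c2nc(-c3ccc4ccccc4n3)no2)CC1` has not yet been measured. It differs from compound 2 in one place: 2-methoxyphenyl in place of cyclobutylmethyl on an amide-type nitrogen. Within the data shown here, no measured pair shows this exact change, so the size of the step must be judged from the numbers above alone. The step from compound 2 to compound 4 is expected to be small and toward a lower number, near the edge of the scatter, a 1.9-fold lower number from compound 2 to compound 4 (0.27 log units; within the scatter). Compound 4 is estimated at 220 nM, with a range from 70 nM to 700 nM.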

Compound 4, half-maximal inhibitory concentration: 410 nM
Compound 4: the middle estimate sits 1.9-fold (0.27 log units) below what was measured; measured number inside the range.
By their numbers in this assay, from the lowest: compound 1; then compounds 3, 2 and 4 (each within the scatter of the next).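

In this assay, putting 2-methoxyphenyl in place of cyclobutylmethyl on an amide-type nitrogen gives no change at the digits printed from compound 2 to compound 4 (within the scatter), the first one-place comparison among these compounds. This position therefore takes either a four-membered non-aromatic ring group or a six-membered aromatic one, with no shift in the read-out beyond the scatter. Nothing measured here offers an explanation for this result. Still open, from the compounds shown here alone, is whether an unsubstituted phenyl would behave like 2-methoxyphenyl. Going by these compounds, it is also open whether a group of another kind at this position, such as a carboxylic acid or an amine, would move the number.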